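Removing the Cyclohexyl Group From a Biaryl Sulfonamide

The source may hold more compounds than are shown below. What is called first, only, known or untested is meant among the compounds shown, and "the series" means these compounds.

Measured compounds:
- compound 1, `O=C1COc2ccc(-c3ccc(O)cc3)cc2N1`: in a functional assay on HCT-116 cells (Homo sapiens) for antiproliferative activity, read by MTT assay, with a stated time of 72 h (a lower number here means a stronger inhibitor, a higher number a weaker inhibitor), compound 1 gives > 40000 nM, which is a limit of the assay.
- compound 2, `O=C1COc2ccc(-c3cnc(Cl)c(NS(=O)(=O)c4ccc(F)cc4)c3)cc2N1C1CCCCC1`: in this assay compound 2 gives > 40000 nM, likewise a limit.
- compound 3, `COc1ncc(-c2ccc3c(c2)N(C2CCCCC2)C(=O)CO3)cc1NS(=O)(=O)c1ccc(F)cc1`: in this assay compound 3 gives > 40000 nM, again a limit.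

Compound 2 therefore stands only at a limit in this assay, and the other two values shown sit at the same limit, as the limit of > 40000 nM in this assay, at which 3 of the 3 values shown sit, records. Among the measured compounds shown here, the single measured step, a step that the two limits leave unreadable from compound 2 to compound 3, cannot be sized from the two limits. Compound 4, `O=C1COc2ccc(-c3cnc(Cl)c(NS(=O)(=O)c4ccc(F)cc4)c3)cc2N1`, differs from compound 2 by hydrogen in place of cyclohexyl on an amide-type nitrogen in a ring. For the measured compounds named here, compound 1 carries a hydrogen at that same position and also sits at the limit, so no measured step points to a gain in potency on this change. For compound 4 in this assay the value is expected to remain at or near the limit, the step that the limit leaves unreadable from compound 2 to compound 4 being an estimate and not a reading. The estimate for compound 4 is 60000 nM, with an expected range from 30000 nM to 150000 nM.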

Compound 4, half-maximal inhibitory concentration: > 40000 nM
Compound 4 was reported as a limit (the forecaster's own chance of this, stated with the estimate: 85%); the middle value does not contradict the limit.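

No step can be read from compound 2 to compound 4, as both values are limits in this assay: the limit of > 40000 nM in this assay, at which 4 of the 4 values shown sit.

The compounds shown leave open whether any of them has antiproliferative activity in this assay, and how large the effect of replacing cyclohexyl with hydrogen is.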